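Swapping Chloro for Indolyl: What Happens to Cell Toxicity?

The source may report more compounds than this note shows. Statements on the series, on what has been measured and on what is new or still open speak of the compounds shown alone.

Among the compounds with values here, in an ADME assay on MRC5 cells (Homo sapiens) for cytotoxicity, read by neutral red uptake, with a stated time of 24 h (a higher number here means a weaker inhibitor, a lower number a stronger inhibitor), compound 1 `CC(C)c1cc2c3c(c1OC(=O)CCl)OC(=O)[C@@]31CCCC(C)(C)[C@@H]1CC2` gives 130000 nM, the only exact number so far. Compound 2 `CCCCCCCC/C=C/CCCCCCCC(=O)Oc1c(C(C)C)cc2c3c1OC(=O)[C@@]31CCCC(C)(C)[C@@H]1CC2` gives > 1000000 nM, which is a limit of the assay and not a number.

The next compound, compound 3 `CC(C)c1cc2c3c(c1OC(=O)Cc1c[nH]c4ccccc14)OC(=O)[C@@]31CCCC(C)(C)[C@@H]1CC2`, differs from compound 1 in one place: 1H-indol-3-yl in place of chloro on a saturated chain carbon bound to a carbonyl carbon. In words, this puts 1H-indol-3-yl in place of chloro on a saturated chain carbon bound to a carbonyl carbon.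

Within the data shown here, compound 2 also lacks the chloro and is the only guide here, and its limit of > 1000000 nM points towards higher numbers. A modest step towards a higher number, meaning a weaker effect on the cells, is therefore expected in this assay, estimated as a 1.9-fold higher number from compound 1 to compound 3 (0.28 log units; within the scatter). For compound 3 the expected value is 250000 nM, with an estimated range of 70000 nM to 900000 nM.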

Compound 3, half-maximal inhibitory concentration: 109000 nM
Estimate against measurement, compound 3: 2.3-fold (0.36 log units) above; the range from low to high includes it.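

Within the data shown here, until now, this position had no exact step to read, and compound 3 supplies the first: 1H-indol-3-yl, with 9 heavy atoms and a hydrogen-bond donor, replaces chloro, with 1 heavy atom, on the saturated chain carbon bound to a carbonyl carbon. In this assay this large swap gives a 1.2-fold lower number from compound 1 to compound 3 (0.08 log units; within the scatter), so the two compounds cannot be told apart, and in this pair the read-out does not depend on keeping chloro. Compound 2 still offers no number for comparison, only a limit of the assay: the limit of > 1000000 nM in this assay, at which 1 of the 3 values shown sits.

Going by these compounds, what a simple amine or a carboxylic acid on this same carbon would do remains open. So does whether a 1H-indol-3-yl group set on a longer chain would leave the number in the same place.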